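Replacing the (morpholin-4-yl)carbonyl group of compound 2

The source may report more compounds than this note shows. Statements on the series, on what has been measured and on what is new or still open speak of the compounds shown alone.

Values in a functional assay with Oryctolagus cuniculus as the target (on this read-out higher numbers stand for weaker inhibition and lower numbers for stronger inhibition), so far:
Compound 1 `COc1ccc(-c2nc(/N=C(\N)[N+]3(C)CCCCC3)sc2-c2ccc(OC)cc2)cc1` gives > 1000 nM as a limit of the assay
Compound 2 `COc1ccc(-c2nc(C(=O)N3CCOCC3)sc2-c2ccc(OC)cc2)cc1` gives < 10 nM as a limit of the assay

Compound 2 stands at the limit of < 10 nM in this assay, at which 1 of the 2 values shown sits, and so has no exact number. Compound 3 `COc1ccc(-c2nc(C3=NNC(=O)CC3)sc2-c2ccc(OC)cc2)cc1` has not yet been measured. Among the measured compounds shown here, it keeps the core of compound 2 and swaps the (morpholin-4-yl)carbonyl group for a different ring group, as follows: a group of 7 heavy atoms (4 carbon, 2 nitrogen, 1 oxygen; one six-membered non-aromatic ring with 2 hetero atoms) in place of a group of 8 heavy atoms (5 carbon, 1 nitrogen, 2 oxygen; one six-membered non-aromatic ring with 2 hetero atoms), on an aromatic carbon and this is the only change.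

For the measured compounds named here, one measured step bears on this position, an at least 100-fold lower number from compound 1 to compound 2 (2.00 log units; beyond the scatter) and it is large and beyond the scatter. It starts from a different group, however, and both of its ends are limits, so it gives no size for the present change. It shows only that the position can matter in this assay for these compounds. The entering and leaving groups are both uncharged six-membered non-aromatic rings with 2 hetero atoms, so no step beyond the scatter is expected. The expected change is a number no lower from compound 2 to compound 3 (the limit leaves the size open) with much uncertainty. In this assay compound 3 is expected to give 10 nM with an estimated range from 1 nM to 100 nM for the coming measurement.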

Compound 3, half-maximal inhibitory concentration: > 1000 nM
Compound 3 ended at the assay's limit (the forecaster's own chance of this, stated with the estimate: 55%); middle value at least 100-fold (2.00 log units) from the limit.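

In this assay, exchanging one uncharged ring group for another gives an at least 100-fold higher number from compound 2 to compound 3 (2.00 log units; beyond the scatter), and both ends of this step are limits of the assay. The earlier step set the (morpholin-4-yl)carbonyl group against a group of a different kind, whereas this one shows that a group with no net charge and a six-membered non-aromatic ring with 2 hetero atoms, like the group it replaces, still does not keep the strength of compound 2. Among the compounds shown, only the (morpholin-4-yl)carbonyl group reaches the low limit, while the other two groups share the high one: the limit of > 1000 nM in this assay, at which 2 of the 3 values shown sit.

The step from compound 1 to compound 3 cannot be read, and the compounds shown do not tell whether the outcome follows the carbonyl attached to the ring nitrogen, the ring oxygen of the morpholine or the hydrogen-bond donor that enters. A piperidin-1-ylcarbonyl or a dimethylaminocarbonyl group at this position would help to separate these features, and values away from the limits would be needed to give the step a size.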